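The compounds below may be only part of what the source reports. "The series", "measured", "known", "first", "only" and "open" are said of these compounds alone.

Working notes on the series.

Compound 2 `CCCCOc1cc(C)c(-c2cccc(COc3ccc(OCC(=O)O)c(F)c3)c2)c(C)c1` stands as "not determined" (no result reported) in a functional assay on CHO cells for agonist activity at Free fatty acid receptor 1 (Homo sapiens), read by FLIPR and calcium flux; on this read-out higher numbers stand for an effect only at larger amounts of compound and lower numbers for an effect already at smaller amounts: for compound 2 no result was reported, so nothing can be said about where it lies. Within the data shown here, the two measured members frame the range: compound 1 `Cc1cc(O)cc(C)c1-c1cccc(COc2ccc(OCC(=O)O)c(F)c2)c1` gives 110 nM in this assay, and compound 3 `Cc1cc(OCCCS(C)(=O)=O)ccc1-c1cccc(COc2ccc(OCC(=O)O)c(F)c2)c1` gives 43.6 nM in this assay; these two values sit close to one another.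

Compound 4 `COc1cc(C)c(-c2cccc(COc3ccc(OCC(=O)O)c(F)c3)c2)c(C)c1` differs from compound 2 by hydrogen in place of propyl on a saturated chain carbon bound to an oxygen on an aromatic ring, or butoxy to methoxy. Among the measured compounds shown here, without a number for compound 2, no step in this assay can be anchored, and no direction is assigned to it; the change is small in heavy-atom count and a step within the scatter, if any, is the working assumption.

The estimate for compound 4 therefore rests on compound 1 and compound 3 alone: compound 4 is expected at about 120 nM in this assay, with a range from 40 nM to 400 nM.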

Compound 4, half-maximal effective concentration: 49.7 nM
Compound 4: the middle estimate sits 2.4-fold (0.38 log units) above what was measured, and the stated range covers the measured number.
By their numbers in this assay, from the lowest: compounds 3 and 4 (each within the scatter of the next); then compound 1.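

In this assay the oxygen on the aromatic ring now gives a first readable step, a 2.2-fold lower number from compound 1 to compound 4 (0.35 log units; beyond the scatter), with methyl in place of hydrogen on that oxygen. The earlier compounds shown here offered no such pair: compound 2 carries no number, so the step from it to compound 4 cannot be read. Nothing at hand bears on why the number moves with this change.

Going by these compounds, whether the length of the chain on this oxygen matters stays open, since butoxy has no value to set against methoxy. Also open, on these data alone, is how ethoxy, or a longer chain ending in an amine or a carboxylic acid, would read on the same oxygen in this assay.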